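Chain extension of the aryloxy acid on two cores

The source may report more compounds than this note shows. Statements on the series, on what has been measured and on what is new or still open speak of the compounds shown alone.

Compound 1 `CCCc1c(OCCCCCOc2c(C(C)=O)ccc(OCC(=O)O)c2CCC)ccc(C(C)=O)c1O` and compound 2 `CCCc1c(OCCCCCOc2c(C(C)=O)ccc(OCCCC(=O)O)c2CCC)ccc(C(C)=O)c1O` share one core, while compound 3 `CCCc1c(OCCCOc2ccc3ccc(OCC(=O)O)cc3c2)ccc(C(C)=O)c1O` and compound 4 `CCCc1c(OCCCOc2ccc3ccc(OCCCC(=O)O)cc3c2)ccc(C(C)=O)c1O` share another; the difference between the two cores is not broken down here. In a functional assay on ileum (Cavia porcellus) for inhibition of cysteinyl leukotriene receptor (Homo sapiens) (on this read-out higher numbers stand for weaker inhibition and lower numbers for stronger inhibition), compound 1 gives 100 nM, compound 2 gives 1000 nM and compound 3 gives 300 nM. Compound 3 thus stands between its two neighbours, with a lower number than compound 2 and a higher one than compound 1.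

The change from compound 1 to compound 2 is 2-carboxyethyl in place of carboxy on a saturated chain carbon bound to an oxygen on an aromatic ring and this assay shows a 10-fold higher number from compound 1 to compound 2 (1.00 log units; beyond the scatter). The change from compound 3 to compound 4 is 2-carboxyethyl in place of carboxy on a saturated chain carbon bound to an oxygen on an aromatic ring. The place of the change is described in the same words in both pairs, so this is the same change, carried over from one core to the other; it occurs twice among the compounds shown.

Among the compounds with values here, only one measured instance of this change exists, and it sits on a different core, so the expectation for compound 4 rests on that single step and on the value of compound 3. The expected step for compound 4 is an 8.3-fold higher number from compound 3 to compound 4 (0.92 log units; beyond the scatter) because the earlier instance in this assay gave a 10-fold higher number from compound 1 to compound 2 (1.00 log units; beyond the scatter), and some allowance is made for the change of core, which could dampen or sharpen the effect. Compound 4 is therefore estimated at 2500 nM, with a range from 800 nM to 8000 nM.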

Compound 4, half-maximal inhibitory concentration: 5000 nM
For compound 4 the middle estimate is 2.0-fold (0.30 log units) below the measured one; low and high end bracket the measured number.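

In this assay the change from carboxymethoxy to 3-carboxypropoxy gives a 17-fold higher number from compound 3 to compound 4 (1.22 log units; beyond the scatter), and the two instances of this change do not differ beyond the scatter: the same change on two cores in this assay, a 10-fold higher number (1.00 log units; beyond the scatter) from compound 1 to compound 2 and a 17-fold higher number (1.22 log units; beyond the scatter) from compound 3 to compound 4, 1.7-fold (0.22 log units) apart, within the scatter of two such steps

On these two cores, then, the change travels in the same direction and at a comparable size, so the step measured on one core was a usable guide to the step on the other. The two pairs agree closely enough that no dependence on the core can be read from them, but a difference too small to stand out from the scatter of two steps cannot be excluded either. Two pairs do not establish a rule for the whole series, and they say nothing about why the longer acid chain gives the higher number or which part of either core, if any, governs the size of the step.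

The compounds shown leave open how the number runs with chain length, since only carboxymethoxy and 3-carboxypropoxy appear, with no 2-carboxyethoxy chain and no chain longer than 3-carboxypropoxy. They also leave open whether the same step holds on a third core, or when a tetrazole or an amide stands in place of the carboxylic acid.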